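Swapping a polar group for fluorine on the shared core

The source may report more compounds than this note shows. Statements on the series, on what has been measured and on what is new or still open speak of the compounds shown alone.

The compounds share one core, and differ only in the group carried on the outer six-membered ring of carbon atoms. Compound 1 `Cn1nc2c(=O)n(CC3(O)CCN(Cc4ccc(-c5ccco5)cc4Cl)CC3)cnc2c1-c1ccc(CNS(C)(=O)=O)cc1` gives 65.3 nM in an assay on isolated protein for inhibition of ubiquitin carboxyl-terminal hydrolase 7 (Homo sapiens), with stated times of 30 min and 2 h; a higher number here means a weaker inhibitor, a lower number a stronger inhibitor. Compound 2 `Cn1nc2c(=O)n(CC3(O)CCN(Cc4ccc(-c5ccco5)cc4Cl)CC3)cnc2c1-c1ccc(C(=N)N)cc1` gives 87.5 nM in this assay, which is the higher of the two numbers; the step of a 1.3-fold higher number from compound 1 to compound 2 (0.13 log units; within the scatter) lies within the scatter, so the two cannot be ranked. Compound 3 `Cn1nc2c(=O)n(CC3(O)CCN(Cc4ccc(-c5ccco5)cc4Cl)CC3)cnc2c1-c1ccc(F)cc1` carries the change (one fluorine atom in place of a group of 3 heavy atoms (1 carbon, 2 nitrogen; no ring), on an aromatic carbon), on an aromatic carbon of a six-membered aromatic ring of carbon only, para to a large group. Within the data shown here, no measured step bears directly on this change; the only step available, a 1.3-fold higher number from compound 1 to compound 2 (0.13 log units; within the scatter), exchanged one polar group for another without a shift beyond the scatter. The expectation is therefore a modest step at most, a 1.7-fold higher number from compound 2 to compound 3 (0.23 log units; within the scatter), with wide uncertainty. Compound 3 is estimated at 150 nM in this assay, within a range from 50 nM to 600 nM.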

Compound 3, half-maximal inhibitory concentration: 64.5 nM
Beside the measured number, compound 3's estimate is 2.3-fold (0.37 log units) above it, within the range that was stated.
By their numbers in this assay, from the lowest: compounds 3, 1 and 2 (each within the scatter of the next).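

In this assay the step is a 1.4-fold lower number from compound 2 to compound 3 (0.13 log units; within the scatter) when fluoro replaces the group of 3 heavy atoms, and a 1.0-fold lower number from compound 1 to compound 3 (0.01 log units; within the scatter) when fluoro replaces (methanesulfonamido)methyl. Among these compounds, the earlier pair showed only one multi-atom group exchanged for another, whereas these steps show that a single fluorine atom, with 0 hydrogen-bond donors and 0 hydrogen-bond acceptors, on this aromatic carbon cannot be told apart from either larger group. Among these three compounds, then, the number does not separate the groups by size or by donor count, and nothing available here explains that result.

As far as these compounds go, whether a group such as an amine, a carboxylic acid or a longer chain on this aromatic carbon would also stay within the scatter remains open. So does the result with plain hydrogen at this place, which would show whether the fluorine itself matters.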